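Thiophen-3-yl for phenyl on the core of compound 1

A few compounds are considered here, and "the series" means these few. Any claim that something is new, unique, unknown or untested is made for them only; others in the source may bear on it.

Measured so far:
compound 1 `CC(c1ccc(-c2ccccc2)nc1)n1ccnc1` — 33 nM
compound 2 `c1ccc(-c2ccc(C(c3ccccc3)n3ccnc3)cn2)cc1` — 124 nM

In an in vitro assay on V79MZh cells for inhibition of cytochrome P450 11B1, mitochondrial (Homo sapiens) (on this read-out lower numbers stand for stronger inhibition and higher numbers for weaker inhibition), compound 1 gives 33 nM, the lowest of the two numbers recorded; compound 2 gives 124 nM. Going by the values given here, the single measured step, a 3.8-fold higher number from compound 1 to compound 2 (0.57 log units; beyond the scatter), concerns the saturated chain carbon bound to the aromatic carbon and the aromatic nitrogen, not the aryl end of the core.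

Compound 3 `CC(c1ccc(-c2ccsc2)nc1)n1ccnc1` differs from compound 1 by thiophen-3-yl in place of phenyl on an aromatic carbon. Among the compounds with values here, no measured step touches this aromatic position, so the recorded step bears on it only as a reminder that the series tolerates changes of modest size. With nothing in the data pointing in either direction, the working expectation is a change not beyond the scatter. Compound 3 is therefore expected near 35 nM, with a range from 15 nM to 90 nM. The step this estimate implies, a 1.1-fold higher number from compound 1 to compound 3 (0.03 log units; within the scatter), is expected to stay within the usual repeat variation.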

Compound 3, half-maximal inhibitory concentration: 21 nM
The estimate for compound 3 lay 1.7-fold (0.22 log units) above the measured number; the measured number falls inside the stated range.
By their numbers in this assay, from the lowest: compounds 3 and 1 (each within the scatter of the next); then compound 2.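

In this assay, going by these compounds alone, the exchange of phenyl for thiophen-3-yl on the aromatic carbon next to the ring nitrogen (a 1.6-fold lower number from compound 1 to compound 3 (0.20 log units; within the scatter)) gives the first reading at this position, which the earlier step left untouched. The five-membered aromatic ring with 1 hetero atom, at 5 heavy atoms against 6, leaves compound 3 and compound 1 within the scatter of each other, so this position accepts a sulfur-containing ring in place of a six-membered aromatic ring of carbon only. No independent measurement bears on why the two compounds read alike.

On these data alone, whether the same holds for thiophen-2-yl, pyridin-3-yl or an open chain such as n-butyl at this position remains open. Also open, as far as these compounds go, is whether thiophen-3-yl behaves the same way on the core of compound 2, which carries phenyl on the chain carbon.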